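Dropping the Drawn Configuration at the Chain Carbon

The compounds below may be only part of what the source reports. "The series", "measured", "known", "first", "only" and "open" are said of these compounds alone.

Compound 1 `C[C@H](C(=O)Nc1cc(C2CC2)[nH]n1)c1ccc(N2CCCC2)cc1` is the reference point: in a functional assay on A2780 cells (Homo sapiens) for inhibition (on this read-out higher numbers stand for weaker inhibition and lower numbers for stronger inhibition), compound 1 gives 220 nM. Going by the values given here, compound 2 `C[C@H](C(=O)Nc1cc(C2CC2)[nH]n1)c1ccc(N2CCNC2=O)cc1` carries 2-oxoimidazolidin-1-yl in place of pyrrolidin-1-yl on an aromatic carbon, and in this assay compound 2 gives 1270 nM, the highest of the two numbers measured so far; the single measured step is a 5.8-fold higher number from compound 1 to compound 2 (0.76 log units; beyond the scatter).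

Compound 3 `CC(C(=O)Nc1cc(C2CC2)[nH]n1)c1ccc(N2CCNC2=O)cc1` keeps every atom and bond of compound 2 and differs only in one way: the two compounds have the same atoms and bonds; at least one stereo element is drawn with a configuration in one of them and without one in the other: 1 of 1 stereo elements differ; a stereocentre at a saturated chain carbon is drawn S in compound 2 and without a configuration in compound 3.

Among the compounds with values here, no measured step bears on this change. Within the data shown here, the one step on record concerns the exchange of a ring on an aromatic carbon, not a stereo element, so it offers no guide here. Without a drawn configuration the material may be a mixture, and the expectation is a number no lower than that of compound 2, either within the scatter or modestly higher. For compound 3 the estimate in this assay is 1900 nM, in the range 900 nM to 4200 nM, which means an expected step of a 1.5-fold higher number from compound 2 to compound 3 (0.17 log units; within the scatter).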

Compound 3, half-maximal inhibitory concentration: 2250 nM
Compound 3: the middle estimate sits 1.2-fold (0.07 log units) below what was measured; the range from low to high includes it.
By their numbers in this assay, from the lowest: compound 1; then compounds 2 and 3 (each within the scatter of the next).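

In this assay the change at the saturated chain carbon is a 1.8-fold higher number from compound 2 to compound 3 (0.25 log units; within the scatter), so removing the drawn configuration leaves no difference that can be told from the scatter. The earlier step spoke only to the group on the aromatic carbon, with this stereocentre drawn S in both compounds, whereas this pair bears on the stereocentre itself. Even so, the comparison sets a defined drawing against an undefined one, not one configuration against its opposite: the fact that one of compounds 2 and 3 is drawn with a defined configuration and the other without, at the place where they differ

The compounds shown leave open how the R configuration alone would read, and whether the same result would hold with pyrrolidin-1-yl in place of 2-oxoimidazolidin-1-yl. They also leave open what an ethyl group or a hydroxyl group at the saturated chain carbon would do.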